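From Amino to 4-chloro-3-(trifluoromethyl)phenyl

The compounds below may be only part of what the source reports. "The series", "measured", "known", "first", "only" and "open" are said of these compounds alone.

In a functional assay on NCI-H460 cells (Homo sapiens) for inhibition, read by MTT assay, with a stated time of 4 days (a lower number here means a stronger inhibitor, a higher number a weaker inhibitor), compound 1 (`COc1cc(NC(C)CCCNC(=O)NN)c2ncccc2c1`) gives > 100000 nM as a limit and not a number. Compound 2 (`COc1ccc(/C(=N/NC(=O)NCCCC(C)Nc2cc(OC)cc3cccnc23)c2ccccc2)cc1`) likewise gives > 100000 nM as a limit. Compound 1 thus stands at the limit of > 100000 nM in this assay, at which 2 of the 3 values shown sit, with no measured potency. Compound 3 (`COc1cc(NC(C)CCCNC(=O)NNC(=O)NCCNC(c2ccccc2)(c2ccccc2)c2ccccc2)c2ncccc2c1`) alone gives a number, 4000 nM in this assay as a true reading, though compound 2 shows that added aromatic rings do not guarantee one. Among the compounds with values here, compound 4 (`COc1cc(NC(C)CCCNC(=O)Nc2ccc(Cl)c(C(F)(F)F)c2)c2ncccc2c1`) carries 4-chloro-3-(trifluoromethyl)phenyl in place of amino on an amide-type nitrogen and no measured step covers this change. A large move toward stronger inhibition is expected, estimated as an at least 12-fold lower number from compound 1 to compound 4 (1.09 log units; beyond the scatter) on the strength of compound 3 alone. For compound 4 an estimated 8000 nM is expected with a range from 2000 nM to 40000 nM as the likely span.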

Compound 4, half-maximal inhibitory concentration: 28000 nM
Estimate against measurement, compound 4: 3.5-fold (0.54 log units) below; the range from low to high includes it.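

In this assay, putting 4-chloro-3-(trifluoromethyl)phenyl in place of amino on the amide-type nitrogen gives an at least 3.5-fold lower number from compound 1 to compound 4 (0.55 log units; beyond the scatter), so a single substituted aromatic ring at this position is enough to yield a true reading. Compound 1 stands at a limit and not a number, so this step fixes only a minimum size for the change: the limit of > 100000 nM in this assay, at which 2 of the 4 values shown sit.

The compounds shown leave open whether the gain comes from the phenyl ring itself, the chlorine or the trifluoromethyl. A plain phenyl, a cyclohexyl ring or a methyl group on this nitrogen would separate these.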